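Aryl for methyl on the chloropyridine-bearing series

A few compounds are considered here, and "the series" means these few. Any claim that something is new, unique, unknown or untested is made for them only; others in the source may bear on it.

Measured compounds:
- compound 1 `COc1cc(-c2cc(COCc3cn(Cc4cc(-c5ccccc5)cnc4Cl)nn3)on2)cc(OC)c1OC` 43100 nM
- compound 2 `COc1cc(-c2cc(COCc3cn(Cc4cc(-c5ccc(C)cc5)cnc4Cl)nn3)on2)cc(OC)c1OC` 35300 nM
- compound 3 `COc1cc(-c2cc(COCc3cn(Cc4cc(C)cnc4Cl)nn3)on2)cc(OC)c1OC` 57700 nM

In a functional assay on HeLa cells (Homo sapiens) for cytotoxicity, read by MTT assay, with a stated time of 48 h (a lower number here means a stronger inhibitor, a higher number a weaker inhibitor), compound 3 gives 57700 nM, a value not separated from those of the other two compounds. Compound 4 `COc1cc(-c2cc(COCc3cn(Cc4cc(-c5ccc(F)cc5)cnc4Cl)nn3)on2)cc(OC)c1OC` carries 4-fluorophenyl in place of methyl on an aromatic carbon, (4-fluorophenyl in place of methyl on an aromatic carbon). The nearest evidence comes from the reverse exchange, a 1.3-fold higher number from compound 1 to compound 3 (0.13 log units; within the scatter) and a 1.6-fold higher number from compound 2 to compound 3 (0.21 log units; within the scatter), while changing the aryl group itself gave a 1.2-fold lower number from compound 1 to compound 2 (0.09 log units; within the scatter). None of these steps leaves the scatter, so no real shift is expected in this assay. The expected step is a 1.4-fold lower number from compound 3 to compound 4 (0.16 log units; within the scatter), which is no step beyond the scatter. For compound 4 the estimated value is 40000 nM, with an expected range of 22000 nM to 70000 nM.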

Compound 4, half-maximal inhibitory concentration: 37300 nM
Compound 4: middle estimate off by 1.1-fold (0.03 log units), on the high side; the measured number falls inside the stated range.
By their numbers in this assay, from the lowest: compounds 2, 4, 1 and 3 (each within the scatter of the next).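

In this assay, 4-fluorophenyl reads no differently from methyl on this aromatic carbon, two atoms from the ring nitrogen (a 1.5-fold lower number from compound 3 to compound 4 (0.19 log units; within the scatter)). Fluoro in place of methyl or hydrogen on the aryl group also leaves the reading within the scatter (a 1.1-fold higher number from compound 2 to compound 4 (0.02 log units; within the scatter); a 1.2-fold lower number from compound 1 to compound 4 (0.06 log units; within the scatter)), so methyl and all three aryl groups remain unseparated at this position. Nothing at hand accounts for this flat reading. Still open, as far as these compounds go, is whether an amine, a carboxylic acid or a longer chain at this position would give a step beyond the scatter.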